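From Two Chlorines to Chlorine and Fluorine

This account rests on a few compounds, and the source may have more. Where it says the series, first, only, none or still open, it means among the compounds named here.

Compound 1, `CN(C)CCn1cnnc1-c1cc(Oc2ccc(NC(=O)N/N=C/c3c(Cl)cccc3Cl)cc2F)ccn1`, is the reference point of this small set. In a functional assay on HT-29 cells (Homo sapiens) for cytotoxicity, read by MTT assay, with a stated time of 72 h (on this read-out lower numbers stand for stronger inhibition and higher numbers for weaker inhibition), compound 1 gives 280 nM, the lowest of the three numbers measured. Compound 2, `COc1ccc(/C=N/NC(=O)Nc2ccc(Oc3ccnc(-c4nncn4CCN(C)C)c3)c(F)c2)c(OC)c1`, carries 2,4-dimethoxyphenyl on the carbon with a double bond to nitrogen, and in this assay compound 2 gives 1780 nM. Compound 3, `CN(C)CCn1cnnc1-c1cc(Oc2ccc(NC(=O)N/N=C/c3ccc(O)c(O)c3)cc2F)ccn1`, carries 3,4-dihydroxyphenyl at that carbon, and in this assay compound 3 gives 1890 nM. The two steps away from compound 1 are a 6.4-fold higher number from compound 1 to compound 2 (0.80 log units; beyond the scatter) and a 6.8-fold higher number from compound 1 to compound 3 (0.83 log units; beyond the scatter), whereas a 1.1-fold higher number from compound 2 to compound 3 (0.03 log units; within the scatter) separates the two oxygen-substituted analogues.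

Compound 4, `CN(C)CCn1cnnc1-c1cc(Oc2ccc(NC(=O)N/N=C/c3ccc(F)cc3Cl)cc2F)ccn1`, has not yet been measured. It differs from compound 1 by 2-chloro-4-fluorophenyl in place of 2,6-dichlorophenyl on a carbon with a double bond to nitrogen. Both measured steps from compound 1 bear on this change: each swapped the 2,6-dichlorophenyl for 2,4-dimethoxyphenyl or 3,4-dihydroxyphenyl and each gave a modest rise in the number. Compound 4 instead keeps a ring bearing only halogens, a smaller departure from compound 1 than either measured step, so for compound 4 only a weaker drift in the same direction is expected, a 1.8-fold higher number from compound 1 to compound 4 (0.25 log units; within the scatter). For compound 4 in this assay the estimate is 500 nM, with a range from 200 nM to 1500 nM.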

Compound 4, half-maximal inhibitory concentration: 510 nM
For compound 4 the middle estimate is 1.0-fold (0.01 log units) below the measured one; low and high end bracket the measured number.
By their numbers in this assay, from the lowest: compounds 1 and 4 (each within the scatter of the next); then compounds 2 and 3 (each within the scatter of the next).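

In this assay, moving from 2,6-dichlorophenyl to 2-chloro-4-fluorophenyl on the carbon with a double bond to nitrogen gives a 1.8-fold higher number from compound 1 to compound 4 (0.26 log units; within the scatter), so this position does not depend on the 2,6-dichlorophenyl group itself, and a second halogen pattern can stand there with compound 1 and compound 4 not told apart. The earlier compounds could show only that two oxygen-bearing rings gave higher numbers than the dichlorinated one, whereas now a 3.7-fold lower number from compound 3 to compound 4 (0.57 log units; beyond the scatter) and a 3.5-fold lower number from compound 2 to compound 4 (0.54 log units; beyond the scatter) show that the new halogen-bearing ring also stands clearly apart from both, and among these four compounds none goes against this division between halogen-bearing and oxygen-bearing rings. What lies behind that division remains unexplained, as no measurement at hand speaks to it.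

Going by these compounds, it stays open whether a ring carrying bromine, a methyl group or a trifluoromethyl group would fall with compound 1 and compound 4 or with compound 2 and compound 3. Also open, on these data alone, is where an unsubstituted phenyl ring, or a ring bearing a single chlorine or an amine, would fall.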